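The source may report more compounds than this note shows. Statements on the series, on what has been measured and on what is new or still open speak of the compounds shown alone.

Measured compounds:
compound 1 `Nc1nn(C(=O)Nc2ccc(Cc3ccccc3)cc2)c2ccccc12` — 5360 nM
compound 2 `Nc1nn(C(=O)Nc2ccc(Cc3ccccc3)cc2)c2ccc(Cl)cc12` — 11500 nM

For the measured compounds named here, in a functional assay on SF-539 cells (Homo sapiens) for antiproliferative activity, read by sulforhodamine B assay, with a stated time of 48 h (on this read-out higher numbers stand for weaker inhibition of growth and lower numbers for stronger inhibition of growth), compound 2 gives 11500 nM, the higher of the two numbers; the only neighbour is compound 1, which in this assay gives 5360 nM. The step between them was a 2.1-fold higher number from compound 1 to compound 2 (0.33 log units; beyond the scatter), a chloro in place of hydrogen on an aromatic carbon. Compound 3 `Nc1ccc2c(c1)c(N)nn2C(=O)Nc1ccc(Cc2ccccc2)cc1` continues from compound 2 by amino in place of chloro on an aromatic carbon. Going by the values given here, the one step that bears on this change is the one in which the chloro entered, a 2.1-fold higher number from compound 1 to compound 2 (0.33 log units; beyond the scatter); removing it again would by that step be expected to bring the number back toward that of compound 1, but no measured step shows what an amino at this place does. Compound 3 is therefore expected to sit between its two neighbours, with a step of a 1.6-fold lower number from compound 2 to compound 3 (0.22 log units; within the scatter) in this assay, and its estimated value is 7000 nM, within a range of 2500 nM to 20000 nM.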

Compound 3, concentration for total growth inhibition: 22100 nM
Compound 3: middle estimate off by 3.2-fold (0.50 log units), on the low side; measured number outside the range, above it.
By their numbers in this assay, from the lowest: compound 1; then compounds 2 and 3 (each within the scatter of the next).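

In this assay, amino in place of chloro on this aromatic carbon does not bring the number back toward that of compound 1, and the two substituted compounds stay within the scatter of each other (a 1.9-fold higher number from compound 2 to compound 3 (0.28 log units; within the scatter)). Set against hydrogen, the amino group gives a 4.1-fold higher number from compound 1 to compound 3 (0.62 log units; beyond the scatter), so among these three compounds both substituents at this place go with weaker inhibition of growth than hydrogen, with no separation between chloro and amino. No measurement shown here accounts for this shared shift.

From the compounds shown here alone, only hydrogen, chloro and amino have been seen at this place, so it remains open how a hydroxyl, a methoxy or a carboxylic acid on the same aromatic carbon would read. Going by these compounds, it is also open whether an amino group elsewhere on the six-membered aromatic ring would give a similar step.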